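The source may hold more compounds than are shown below. What is called first, only, known or untested is meant among the compounds shown, and "the series" means these compounds.

- compound 1 `CC(C)(C)c1cc(NC(=O)Nc2ccc(NC(=O)c3ccc(OC4CCNCC4)cn3)cc2)no1`: 22.1 mL/min/kg
- compound 2 `CCN1CCC(Oc2ccnc(C(=O)Nc3ccc(NC(=O)Nc4cc(C(C)(C)C)on4)cc3)c2)CC1`: "not determined" (no result reported)

Within the data shown here, in an in vivo ADME assay on the whole organism (plasma, strain Sprague-Dawley) for pharmacokinetics, with Rattus norvegicus as the target, read by LC-MS (a lower number here means slower removal, a higher number faster removal of the compound), compound 1 gives 22.1 mL/min/kg, the only number available. Among the measured compounds shown here, compound 2 reads "not determined" (no result reported) and so no measured step exists to show how much a change in this part of the structure matters.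

Compound 3 `CC1(C)CC(Oc2ccc(C(=O)Nc3ccc(NC(=O)Nc4cc(C(C)(C)C)on4)cc3)nc2)CC(C)(C)N1` keeps the core of compound 1 and differs in one place: 2,2,6,6-tetramethylpiperidin-4-yl in place of piperidin-4-yl on an oxygen on an aromatic ring. The change is confined to the group on the oxygen, and the data give no direction for it. No step beyond the usual scatter is therefore expected in this assay, and the estimated change is a 1.1-fold lower number from compound 1 to compound 3 (0.04 log units; within the scatter). The only anchor for this expectation is compound 1 at 22.1 mL/min/kg, so the range is kept wide. For compound 3 the estimated clearance is 20 mL/min/kg, with an expected range of 9 mL/min/kg to 45 mL/min/kg.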

Compound 3, clearance: 11 mL/min/kg
For compound 3 the middle estimate is 1.8-fold (0.26 log units) above the measured one; measured number inside the range.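

In this assay, among these compounds, the exchange of piperidin-4-yl for 2,2,6,6-tetramethylpiperidin-4-yl on the oxygen gives a 2.0-fold lower number from compound 1 to compound 3 (0.30 log units; within the scatter) and so supplies the first measured step at this position. With 10 heavy atoms entering in place of 6, the two compounds are not separated in this read-out, so on this single pair the larger group on the oxygen carries no clearance penalty or gain that can be told from the scatter. No measurement at hand bears on why the two compounds read as they do.

Open, on these data alone, is whether a group of another kind on this oxygen, such as an open-chain amine or a carboxylic acid, would give a step beyond the scatter. Also open, as far as these compounds go, is whether a single methyl group on the piperidine nitrogen would read differently from the unsubstituted ring.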